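A few compounds are considered here, and "the series" means these few. Any claim that something is new, unique, unknown or untested is made for them only; others in the source may bear on it.

Measured so far:
compound 1, `COc1ccc(OC)c(-c2cc(-c3ccc(C(=O)NCC4CC4)s3)on2)c1` — > 30000 nM
compound 2, `CN(Cc1ccc(F)cc1)C(=O)c1ccc(-c2cc(C3=CC(=O)C=CC3=O)no2)s1` — > 30000 nM

In a functional assay on PC-3 cells (Homo sapiens) for cytotoxicity, read by XTT assay, with a stated time of 72 h (on this read-out lower numbers stand for stronger inhibition and higher numbers for weaker inhibition), compound 2 reports only a limit of the assay, not a number. Compound 1 likewise stops at a limit. Among the compounds with values here, both therefore sit at the limit of > 30000 nM in this assay, at which 2 of the 2 values shown sit, and no step between measured compounds can be computed. Compound 3, `COc1ccc(OC)c(-c2cc(-c3ccc(C(=O)N(C)Cc4ccc(F)cc4)s3)on2)c1`, differs from compound 2 by a group of 10 heavy atoms (8 carbon, 2 oxygen; one six-membered aromatic ring of carbon only) in place of a group of 8 heavy atoms (6 carbon, 2 oxygen; one six-membered non-aromatic ring of carbon only), on an aromatic carbon. Within the data shown here, the group that enters is the one compound 1 already carries, and compound 1 shows no measurable inhibition either. No step beyond the scatter is expected. Compound 3 is expected to give 50000 nM, in the range 20000 nM to 200000 nM. The expected step is a step that the limit leaves unreadable from compound 2 to compound 3.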

Compound 3, half-maximal inhibitory concentration: > 30000 nM
Compound 3 gave a limit, no number; the forecaster's own chance of this, stated with the estimate: 85%; the middle value is on the limit's open side.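

Compound 1, compound 2 and compound 3 all stop at a limit, so no step to compound 3 can be read in this assay: the limit of > 30000 nM in this assay, at which 3 of the 3 values shown sit.

The compounds shown leave open which change to this series, if any, would give a measurable number in this assay.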